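Swapping 3,5-dimethoxyphenyl for phenyl on the shared core

The compounds below may be only part of what the source reports. "The series", "measured", "known", "first", "only" and "open" are said of these compounds alone.

Within the data shown here, in a functional assay on HL-60 cells (Homo sapiens) for inhibition, read by MTT assay, with a stated time of 72 h (a higher number here means a weaker inhibitor, a lower number a stronger inhibitor), compound 2 `COc1cc(OC)cc(N2CCN(C(=O)c3oc(C)nc3-c3ccccc3)CC2)c1` gives 19.2 nM, the lower of the two numbers so far, while compound 1 `Cc1nc(-c2ccccc2)c(C(=O)N2CCN(c3ccccc3F)CC2)o1` gives 147 nM. Compound 3 `Cc1nc(-c2ccccc2)c(C(=O)N2CCN(c3ccccc3)CC2)o1` has phenyl in place of 3,5-dimethoxyphenyl on an amine nitrogen in a ring. Among the measured compounds shown here, the one measured step that bears on this is a 7.7-fold lower number from compound 1 to compound 2 (0.88 log units; beyond the scatter), which brought in 3,5-dimethoxyphenyl in place of 2-fluorophenyl at that same place. A step of similar or somewhat smaller size, towards a higher number, is therefore expected in this assay. The expected step is a 5.2-fold higher number from compound 2 to compound 3 (0.72 log units; beyond the scatter). Compound 3 is estimated at 100 nM, with a range of 30 nM to 330 nM.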

Compound 3, half-maximal inhibitory concentration: 39.1 nM
Beside the measured number, compound 3's estimate is 2.6-fold (0.41 log units) above it; the measured number falls inside the stated range.
By their numbers in this assay, from the lowest: compound 2; then compound 3; then compound 1.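

On this ring nitrogen, bare phenyl already gives a low number: dropping the two methoxy groups gives a 2.0-fold higher number from compound 2 to compound 3 (0.31 log units; beyond the scatter) and so only part of the earlier gain is lost. Removing the fluoro alone gives a 3.8-fold lower number from compound 1 to compound 3 (0.58 log units; beyond the scatter) and this shows that the 2-fluorophenyl of compound 1 is worse here than unsubstituted phenyl. The earlier gain therefore has two parts: losing the fluoro, and adding the methoxy groups. From the compounds shown here alone, what an amine or a carboxylic acid on this phenyl would do in this assay stays open. Nothing available explains why these steps occur.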